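The source may report more compounds than this note shows. Statements on the series, on what has been measured and on what is new or still open speak of the compounds shown alone.

Compound 1, `Cn1nnc(C(=O)CCCCCCc2ccccc2)n1`, in an assay on HEK-293T cells for inhibition of diacylglycerol lipase-alpha (Homo sapiens), read by colorimetric assay (a higher number here means a weaker inhibitor, a lower number a stronger inhibitor), gives > 10000 nM, which is a limit of the assay. Compound 2, `CSc1coc(C(=O)CCCCCCc2ccccc2)n1`, gives in this assay > 10000 nM, again a limit. Compound 3, `O=C(CCCCCCc1ccccc1)c1ncc(Cl)o1`, gives in this assay > 10000 nM, once more a limit.

Compound 3 therefore stands at the limit rather than at a number, as do the other two measured compounds; all three sit at the limit of > 10000 nM in this assay, at which 3 of the 3 values shown sit. The three steps among them, a step that the two limits leave unreadable from compound 1 to compound 2, a step that the two limits leave unreadable from compound 1 to compound 3 and a step that the two limits leave unreadable from compound 2 to compound 3, are for that reason unreadable in size, so none of them tells how far any one of these compounds lies beyond the limit.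

Compound 4, `Cc1ccc(-c2cnc(C(=O)CCCCCCc3ccccc3)o2)nc1`, differs from compound 3 by 5-methylpyridin-2-yl in place of chloro on an aromatic carbon. For the measured compounds named here, no measured step concerns a change of this kind: the three recorded steps swap one small five- or six-membered heteroaryl ring or its small substituent for another, and all three are hidden by the limit. The expectation for compound 4 therefore rests on the structural change alone, with no readable precedent. An estimated step of an at least 3.3-fold lower number from compound 3 to compound 4 (0.52 log units; beyond the scatter) from compound 3 to compound 4 is put forward with low confidence. Compound 4 is estimated to give in this assay about 3000 nM, within a range from 300 nM to 20000 nM.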

Compound 4, half-maximal inhibitory concentration: > 10000 nM
Compound 4 was reported as a limit; the forecaster's own chance of this, stated with the estimate: 45%; middle value at least 3.3-fold (0.52 log units) from the limit.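

Compound 4, like compound 3, stands at a limit of the assay and not at a number, so the step between them, 5-methylpyridin-2-yl in place of chloro, cannot be read in size. All the compounds shown sit at the same place: the limit of > 10000 nM in this assay, at which 4 of the 4 values shown sit. They leave open how far each lies beyond that limit and whether any change to the shared core would give a readable value.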